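The source may hold more compounds than are shown below. What is called first, only, known or untested is meant among the compounds shown, and "the series" means these compounds.

In a functional assay, read by spectrophotometry, with a stated time of 30 min, tested at 200 ug/mL (on this read-out lower numbers stand for a weaker effect and higher numbers for a stronger effect at the one concentration tested), compound 2 `O=C(CN1CCN(c2ccccc2)CC1)Nc1nc2ccccc2[nH]1` gives 62.1%. Compound 1 `CN1CCN(CC(=O)Nc2nc3ccccc3[nH]2)CC1` gives 61.6% and stands nearest to it, by a number 0.5 percentage points higher from compound 1 to compound 2 (within the scatter); compound 3 `O=C(CN1CCN(c2ccccc2F)CC1)Nc1nc2ccccc2[nH]1` gives 70.6% and stands furthest, by a number 8.5 percentage points higher from compound 2 to compound 3 (within the scatter), while a number 9 percentage points higher from compound 1 to compound 3 (within the scatter) closes the set. Compound 4 `COc1ccc(N2CCN(CC(=O)Nc3nc4ccccc4[nH]3)CC2)cc1` differs from compound 2 by methoxy in place of hydrogen on an aromatic carbon. The change most like it, a substituent placed on the same aromatic ring in place of hydrogen, gave a number 8.5 percentage points higher from compound 2 to compound 3 (within the scatter), and the exchanges of the whole group on the ring nitrogen gave a number 0.5 percentage points higher from compound 1 to compound 2 (within the scatter) and a number 9 percentage points higher from compound 1 to compound 3 (within the scatter), none of them beyond the scatter. For compound 4 no step beyond the scatter is therefore expected. Compound 4 is estimated at 64%, between 53% and 76%, an expected step of a number 1.9 percentage points higher from compound 2 to compound 4 (within the scatter).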

Compound 4, a percentage reported as activity, at one concentration (the size of the read-out at that concentration, not a potency): 63.7%
The estimate for compound 4 lay 0.3 percentage points above the measured number; the range from low to high includes it.
By their numbers in this assay, from the lowest: compounds 1, 2, 4 and 3 (each within the scatter of the next).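

Going by these compounds alone, compound 4 puts methoxy on the aromatic carbon para to a large group, a place left unsubstituted in the earlier compounds, and in this assay this gives a number 1.6 percentage points higher from compound 2 to compound 4 (within the scatter). Exchanging whole groups on the ring nitrogen gives a number 6.9 percentage points lower from compound 3 to compound 4 (within the scatter) and a number 2.1 percentage points higher from compound 1 to compound 4 (within the scatter), so 4-methoxyphenyl is not separated from 2-fluorophenyl or methyl. Nothing available explains these steps. From the compounds shown here alone, whether an amine or a carboxylic acid at this place, or a longer chain on its oxygen, would move the read-out beyond the scatter remains open.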